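The source may report more compounds than this note shows. Statements on the series, on what has been measured and on what is new or still open speak of the compounds shown alone.

Measured so far, in an in vitro ADME assay on microsomes from liver (Homo sapiens) for metabolic stability; on this read-out higher numbers stand for fast clearance and lower numbers for slow clearance:
- compound 1 `COCc1nc2nc(C)cc(Nc3ccc(C(F)(F)F)cc3)n2n1`: 6.7 mL.min-1.g-1
- compound 2 `Cc1cc(Nc2ccc(S(F)(F)(F)(F)F)cc2)n2nc(C3CC3)nc2n1`: < 5 mL.min-1.g-1 (a limit)
- compound 3 `Cc1cc(Nc2cccc(Cl)c2)n2nc(C(C)(F)F)nc2n1`: 44.4 mL.min-1.g-1

Compound 1 gives 6.7 mL.min-1.g-1, the lower of the two actual numbers in this set. Compound 3 gives 44.4 mL.min-1.g-1, higher than compound 1 by more than the scatter. Compound 2 is reported only as a limit, < 5 mL.min-1.g-1, and so cannot be placed exactly against the other two.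

The next compound to be read is compound 4 `CCOc1nc2nc(C)cc(Nc3ccc(C(F)(F)F)cc3)n2n1`. It keeps the core and the aryl amine of compound 1 and carries ethoxy in place of methoxymethyl on an aromatic carbon. The two have the same atoms, joined differently.

Within the data shown here, no pair of measured compounds differs in only one place, so the series gives no direct measure of what such a change does in this assay. The expectation therefore starts from compound 1 at 6.7 mL.min-1.g-1 and allows only a small upward move, not beyond the scatter. The expected step is a 1.2-fold higher number from compound 1 to compound 4 (0.08 log units; within the scatter).

For compound 4 the estimated value is 8 mL.min-1.g-1, with an expected range from 5 mL.min-1.g-1 to 18 mL.min-1.g-1.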

Compound 4, intrinsic clearance in microsomes: 7 mL.min-1.g-1
Compound 4: middle estimate off by 1.1-fold (0.06 log units), on the high side, within the range that was stated.
By their numbers in this assay, from the lowest: compounds 1 and 4 (each within the scatter of the next); then compound 3. At a limit, below all of these: compound 2.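

In this assay, among these compounds, ethoxy in place of methoxymethyl on an aromatic carbon gives a 1.0-fold higher number from compound 1 to compound 4 (0.02 log units; within the scatter), the first step between two compounds that differ in one place. The position lies between two ring nitrogen atoms on the five-membered aromatic ring, and there the same atoms, joined differently, produce no difference beyond the scatter, at least with the aryl amine of compound 1 and the rest of its structure held constant. That is one pair and one kind of change, so it sets no general rule for this position, and nothing measured here accounts for the result.

Still open, as far as these compounds go, is how this assay responds when the group at this position is of a different kind, such as an amine, a carboxylic acid or a longer chain such as butoxy, since both groups compared here are small ethers of the same atoms. Among the compounds shown here, also open is whether ethoxy and methoxymethyl would read the same way when carried with a different aryl amine, such as the one in compound 3.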